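Carbonyl substituent change on two dihydropyrimidinone cores

The source may report more compounds than this note shows. Statements on the series, on what has been measured and on what is new or still open speak of the compounds shown alone.

Three compounds built on a shared core have been examined in a functional assay on HT-29 cells (Homo sapiens) for inhibition, read by sulforhodamine B assay, with a stated time of 48 h; on this read-out higher numbers stand for weaker inhibition of growth and lower numbers for stronger inhibition of growth. Compound 1 `C=C(C)[C@@H]1CC=C(Cn2cc(COc3cccc(C4NC(=O)NC(C)=C4C(=O)OCC)c3)nn2)CC1` gives 73400 nM in this assay. Compound 3 `C=C(C)[C@@H]1CC=C(Cn2cc(COc3cccc(C4NC(=O)NC(C)=C4C(C)=O)c3)nn2)CC1` carries methyl in place of ethoxy on a carbonyl carbon and gives 86200 nM in this assay, so that the step of a 1.2-fold higher number from compound 1 to compound 3 (0.07 log units; within the scatter) is small. Compound 2 `C=C(C)[C@@H]1CC=C(Cn2cc(COc3ccccc3C3NC(=O)NC(C)=C3C(=O)OCC)nn2)CC1` has the same atoms as compound 1 joined differently; how the two cores differ is not broken down here. Compound 2 reaches only a limit of this assay, (the limit of > 100000 nM in this assay, at which 1 of the 3 values shown sits), and gives > 100000 nM.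

Compound 4 `C=C(C)[C@@H]1CC=C(Cn2cc(COc3ccccc3C3NC(=O)NC(C)=C3C(C)=O)nn2)CC1` has not yet been measured. Among the compounds with values here, it differs from compound 2 by methyl in place of ethoxy on a carbonyl carbon, which is the same change as the one from compound 1 to compound 3, made at a place described in identical words. Compound 4 is therefore expected to show a step that the limit leaves unreadable from compound 2 to compound 4 in this assay, resting on the small step of a 1.2-fold higher number from compound 1 to compound 3 (0.07 log units; within the scatter) and on compound 2 sitting at the limit (the limit of > 100000 nM in this assay, at which 1 of the 3 values shown sits). Compound 4 is estimated at 130000 nM, with a likely range from 70000 nM to 300000 nM, and a limit rather than a number is expected to be the most probable outcome.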

Compound 4, concentration for total growth inhibition: 79600 nM
For compound 4 the middle estimate is 1.6-fold (0.21 log units) above the measured one; the range from low to high includes it.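

In this assay compound 2 gives > 100000 nM, which is a limit of the assay and not a number. Going from ethoxycarbonyl to acetyl on this core gives an at least 1.2-fold lower number from compound 2 to compound 4 (0.09 log units; that floor lies within the scatter), which is only a floor and leaves the true size of the step unknown, while the same change on the core of compound 1 gives a 1.2-fold higher number from compound 1 to compound 3 (0.07 log units; within the scatter). The two steps can be set side by side but not equated, and the pair shows neither that the change carries over from one core to the other nor that it fails to: the same change on two cores in this assay, a 1.2-fold higher number (0.07 log units; within the scatter) from compound 1 to compound 3 and an at least 1.2-fold lower number (0.09 log units; that floor lies within the scatter) from compound 2 to compound 4; the limit leaves it open whether they differ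

The compounds shown leave open how other groups on this carbonyl carbon would read in this assay, such as a carboxylic acid, an amide or a longer chain like butoxy in place of ethoxy. They also leave open whether the series would respond in the same way on any other cell line.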